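Replacing the nitro group of compound 1 with a trifluoromethylphenyl ring

A few compounds are considered here, and "the series" means these few. Any claim that something is new, unique, unknown or untested is made for them only; others in the source may bear on it.

Among the compounds with values here, compound 1 `COc1cc2nc(N3CCN(S(=O)(=O)c4ccc([N+](=O)[O-])cc4)CC3)nc(N)c2cc1OC` gives 36000 nM in a functional assay on PC-3 cells (Homo sapiens) for inhibition (a lower number here means a stronger inhibitor, a higher number a weaker inhibitor), the second highest of the three numbers known. Compound 2 `COc1cc2nc(N3CCN(S(=O)(=O)c4cccc(C(=O)O)c4)CC3)nc(N)c2cc1OC` gives 53000 nM, and the step of a 1.5-fold higher number from compound 1 to compound 2 (0.17 log units; within the scatter) stays within the scatter. Compound 3 `COc1cc2nc(N3CCN(S(=O)(=O)c4cccc5ccccc45)CC3)nc(N)c2cc1OC` gives 14000 nM, so that a 2.6-fold lower number from compound 1 to compound 3 (0.41 log units; beyond the scatter) and a 3.8-fold lower number from compound 2 to compound 3 (0.58 log units; beyond the scatter) both reach beyond the scatter. Compound 4 `COc1cc2nc(N3CCN(S(=O)(=O)c4ccc(-c5ccc(C(F)(F)F)cc5)cc4)CC3)nc(N)c2cc1OC` differs from compound 1 in one place: 4-(trifluoromethyl)phenyl in place of nitro on an aromatic carbon. Within the data shown here, as in the steps to compound 3, an aromatic ring enters on the sulfonyl-bound phenyl, and those two modest steps are the only guide. A modest step lower is therefore expected, a 2.4-fold lower number from compound 1 to compound 4 (0.38 log units; beyond the scatter), so that compound 4 is estimated at 15000 nM, with a range from 5000 nM to 45000 nM.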

Compound 4, half-maximal inhibitory concentration: 3300 nM
Estimate against measurement, compound 4: 4.5-fold (0.66 log units) above, and the stated range ends above it.
By their numbers in this assay, from the lowest: compound 4; then compound 3; then compounds 1 and 2 (each within the scatter of the next).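

The earlier steps shown here, all exchanges of the whole group on the sulfonyl sulfur, moved the number in this assay only modestly or within the scatter. Here, a change at a single aromatic carbon of that group gives an 11-fold lower number from compound 1 to compound 4 (1.04 log units; beyond the scatter) as a large step, so this position accepts the much bigger 4-(trifluoromethyl)phenyl in place of nitro and gains in inhibition. Nothing available explains this gain. Whether the added ring or its trifluoromethyl group accounts for the step stays open, and so does what a plain phenyl or an amine on this carbon would give.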